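The compounds below may be only part of what the source reports. "The series", "measured", "known", "first", "only" and "open" are said of these compounds alone.

In a functional assay on SK-BR-3 cells (Homo sapiens) for antiproliferative activity, with a stated time of 48 h (on this read-out higher numbers stand for an effect only at larger amounts of compound and lower numbers for an effect already at smaller amounts), compound 1 `Nc1ccc(NC(=O)CCCCCCC(=O)NO)cc1` gives 8500 nM, and compound 2 `O=C(CCCCCCC(=O)Nc1ccc(Cl)cc1)NO` gives 2300 nM, the lower of these two numbers. Compound 3 `O=C(CCCCCCC(=O)Nc1ccc([N+](=O)[O-])cc1)NO` is the next compound to consider. It departs from compound 2 by one change, nitro in place of chloro on an aromatic carbon, para to a large group. Going by the values given here, only one measured step bears on this place, a 3.7-fold lower number from compound 1 to compound 2 (0.57 log units; beyond the scatter), a modest move beyond the scatter when chloro replaced amino. Among the compounds with values here, no measured compound yet shows what nitro does here, so that step offers only a rough guide to how much this position can matter, and it gives no direction for the new change. The expected result is a 1.3-fold higher number from compound 2 to compound 3 (0.12 log units; within the scatter), which means no step beyond the scatter is expected. Compound 3 is estimated at 3000 nM, with an expected range from 1000 nM to 8000 nM.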

Compound 3, half-maximal effective concentration: 58000 nM
The estimate for compound 3 lay 19-fold (1.29 log units) below the measured number, and the stated range ends below it.
By their numbers in this assay, from the lowest: compound 2; then compound 1; then compound 3.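

In this assay, going by these compounds alone, this position proves far more sensitive than the earlier pair could show: nitro in place of chloro gives a 25-fold higher number from compound 2 to compound 3 (1.40 log units; beyond the scatter), a large move where the only earlier step was modest. Nitro also separates from amino, with a 6.8-fold higher number from compound 1 to compound 3 (0.83 log units; beyond the scatter), so the three groups now fall in a clear order, from chloro through amino to nitro, with every step between them beyond the scatter. No measurement at hand says why nitro stands so far from the other two groups.

Going by these compounds, three groups on one aromatic carbon are too few to give a rule, and where a group such as methoxy, fluoro or a carboxylic acid would fall in this order stays open. On these data alone, whether the same order would hold with a longer chain also remains unknown.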